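Ring swap on the exocyclic chain carbon: compound 3

A few compounds are considered here, and "the series" means these few. Any claim that something is new, unique, unknown or untested is made for them only; others in the source may bear on it.

Among the compounds with values here, compound 2 `CN(C)CC[C@H](CSc1ccccc1)Nc1ccc(S(=O)(=O)NC(=O)c2ccc(N3CCC(=Cc4ccccc4C#N)CC3)cc2)cc1[N+](=O)[O-]` gives the highest of the two numbers so far in an assay on isolated protein for displacement of a labelled ligand from Apoptosis regulator Bcl-2 (Homo sapiens), read by fluorescence polarization (a lower number here means a stronger inhibitor, a higher number a weaker inhibitor), at 13 nM. Its nearest neighbour, compound 1 `CN(C)CC[C@H](CSc1ccccc1)Nc1ccc(S(=O)(=O)NC(=O)c2ccc(N3CCC(=Cc4ccccc4C(F)(F)F)CC3)cc2)cc1[N+](=O)[O-]`, gives 2 nM in this assay. Within the data shown here, the one measured step is a 6.5-fold higher number from compound 1 to compound 2 (0.81 log units; beyond the scatter). Compound 3 `CN(C)CC[C@H](CSc1ccccc1)Nc1ccc(S(=O)(=O)NC(=O)c2ccc(N3CCC(=Cc4ccccn4)CC3)cc2)cc1[N+](=O)[O-]` differs from compound 2 by pyridin-2-yl in place of 2-cyanophenyl on a double-bonded chain carbon bound to a double-bonded ring carbon. That single step bears on the same position but changed only a substituent, not the ring, so it sets a rough scale rather than a direction. For compound 3 a further modest rise in this assay is expected, a 2.3-fold higher number from compound 2 to compound 3 (0.36 log units; beyond the scatter). The estimate for compound 3 is 30 nM, range 8 nM to 120 nM.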

Compound 3, inhibition constant: 46 nM
For compound 3 the middle estimate is 1.5-fold (0.19 log units) below the measured one, within the range that was stated.
By their numbers in this assay, from the lowest: compound 1; then compound 2; then compound 3.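

Changing the ring itself on the double-bonded chain carbon bound to a double-bonded ring carbon moves the number in this assay, with a 3.5-fold higher number from compound 2 to compound 3 (0.55 log units; beyond the scatter) and a 23-fold higher number from compound 1 to compound 3 (1.36 log units; beyond the scatter) as the two steps. Pyridin-2-yl therefore gives the highest number of the three groups at this place, so the reading here depends on more than the choice between trifluoromethyl and cyano. Nothing measured on these compounds accounts for this order.

Left open is how a plain phenyl group would read at this place, which would separate the loss of the substituent from the entry of the ring nitrogen.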